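The source may report more compounds than this note shows. Statements on the series, on what has been measured and on what is new or still open speak of the compounds shown alone.

Going by the values given here, in a functional assay on A549 cells (Homo sapiens) for antiproliferative activity, read by MTT assay, with a stated time of 72 h (on this read-out lower numbers stand for stronger inhibition and higher numbers for weaker inhibition), compound 1 (`COc1ccc(-c2ccc3ncn(-c4cc(OC)c(OC)c(OC)c4)c3c2)cc1O`) gives 200 nM and stands lowest of the two numbers so far, while compound 2 (`COc1ccc(-c2ccc3ncn(-c4cc(OC)c(OC)c(OC)c4)c3c2)cc1F`) gives 1430 nM on the same read-out. The change to compound 3 (`COc1cc(-n2cnc3ccc(-c4ccc(C(F)(F)F)cc4)cc32)cc(OC)c1OC`), still unmeasured, is 4-(trifluoromethyl)phenyl in place of 3-hydroxy-4-methoxyphenyl on an aromatic carbon. Among the compounds with values here, one measured step bears on it, fluoro in place of hydroxy on an aromatic carbon, and it lies beyond the scatter. Within the data shown here, compound 3 lacks the hydroxy too, so with a 7.2-fold higher number from compound 1 to compound 2 (0.85 log units; beyond the scatter) as the only guide, a step of similar size is expected in this assay towards weaker inhibition. Among the measured compounds shown here, no measured compound carries trifluoromethyl, so the range stays wide. The estimated change is a 9.0-fold higher number from compound 1 to compound 3 (0.95 log units; beyond the scatter) in the direction of a higher number. For compound 3 the expected value is 1800 nM with an estimated range from 600 nM to 6000 nM on this read-out.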

Compound 3, half-maximal inhibitory concentration: 3390 nM
For compound 3 the middle estimate is 1.9-fold (0.27 log units) below the measured one; the measured number falls inside the stated range.
By their numbers in this assay, from the lowest: compound 1; then compound 2; then compound 3.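

Working notes on the aryl position of the shared core: in this assay the swap of the whole aryl group gives a 17-fold higher number from compound 1 to compound 3 (1.23 log units; beyond the scatter) and so reaches well past the loss of the hydroxy alone. With the hydroxy already absent, the change still counts, since a 2.4-fold higher number from compound 2 to compound 3 (0.37 log units; beyond the scatter) places 4-(trifluoromethyl)phenyl behind 3-fluoro-4-methoxyphenyl at this position, so the remaining substituents on this ring also bear on the number. No supporting measurement is available to account for either step.

Compound 3 changes the methoxy and the ring's other substituent together, so the share of each in the step stays unresolved. Also open, from the compounds shown here alone, is whether an amine in place of the hydroxy, or a 4-methoxyphenyl group with no further substituent, would stay near compound 1 at 200 nM on this read-out.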